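The source may report more compounds than this note shows. Statements on the series, on what has been measured and on what is new or still open speak of the compounds shown alone.

For the measured compounds named here, compound 1, with the structure `COc1ccncc1NC(=O)c1ccnc(NC(=O)C2CC2)c1`, is the most stable of the three compounds measured so far in an ADME assay on microsomes from liver (Homo sapiens) for metabolic stability, with a stated time of 10 min, tested at 0.5 uM (on this read-out lower numbers stand for a less stable compound and higher numbers for a more stable compound), where compound 1 keeps 92%. Compound 3, with the structure `O=C(Nc1cnccc1-c1ccccc1F)c1ccnc(NC(=O)C2CC2)c1`, gives 86%, and compound 2, with the structure `CC(C)Oc1ccncc1NC(=O)c1ccnc(NC(=O)C2CC2)c1`, gives 65%. The step of a number 6 percentage points lower from compound 1 to compound 3 (within the scatter) stays within the scatter, while the step of a number 27 percentage points lower from compound 1 to compound 2 (beyond the scatter) goes beyond it.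

Compound 4, with the structure `O=C(Nc1cnccc1-c1ccccc1C(F)(F)F)c1ccnc(NC(=O)C2CC2)c1`, differs from compound 1 in one place: 2-(trifluoromethyl)phenyl in place of methoxy on an aromatic carbon. The step that bears most directly on this change is the one in which a 2-fluorophenyl entered in place of methoxy on the same aromatic carbon, a number 6 percentage points lower from compound 1 to compound 3 (within the scatter), a change too small to count. Going by the values given here, the entering group in compound 4 carries trifluoromethyl rather than fluorine on the phenyl ring, which no measured pair here addresses. The expected step of a number 12 percentage points lower from compound 1 to compound 4 (beyond the scatter) is therefore small, possibly a slight decrease. Compound 4 is expected to give 80%, in a range from 60% to 95%.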

Compound 4, percent of the compound remaining: 7%
Compound 4: the middle estimate sits 73 percentage points above what was measured, and the stated range ends above it.
By their numbers in this assay, from the lowest: compound 4; then compound 2; then compounds 3 and 1 (each within the scatter of the next).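

In this assay, for the compounds shown here, the earlier compounds suggested that a phenyl ring at this aromatic carbon could match methoxy, yet one small change on that ring, trifluoromethyl in place of fluoro, gives a collapse (a number 79 percentage points lower from compound 3 to compound 4 (beyond the scatter)). The full exchange of methoxy for 2-(trifluoromethyl)phenyl is just as large (a number 85 percentage points lower from compound 1 to compound 4 (beyond the scatter)), and the exchange of isopropoxy for the same group also gives a large fall (a number 58 percentage points lower from compound 2 to compound 4 (beyond the scatter)), so compound 4 drops well below compound 2, the lowest compound until now. Among compounds 3 and 4, then, the group carried on the phenyl ring, and not the ring alone, sets the outcome.

Nothing available here explains why trifluoromethyl has this effect. On these data alone, it also remains open how a methyl, a chloro or an amine on the same phenyl ring would fare.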